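The compounds below may be only part of what the source reports. "The series", "measured", "known", "first", "only" and "open" are said of these compounds alone.

Working notes on the series.

Three compounds have numbers in an ADME assay on microsomes from liver (Mus musculus) for metabolic stability; a lower number here means slower removal, a higher number faster removal of the compound. Compound 1 `COc1cc([C@](O)(CCN(C)C)[C@@H](c2cc3cc(C#N)ccc3nc2OC)c2cccc(C)c2F)cc(OC(F)F)n1` gives 5.9 uL/min in this assay. Compound 2 `COc1cccc([C@H](c2cc3cc(Br)ccc3nc2OC)[C@@](O)(CCN(C)C)c2cc(SC)nc(SC)c2)c1F` gives 17 uL/min. Compound 3 `COc1cccc([C@H](c2cc3cc(C#N)ccc3nc2OC)[C@@](O)(CCN(C)C)c2cc(SC)nc(SC)c2)c1F` gives 20 uL/min, the highest of the three numbers; the nearest is compound 2, with a 1.2-fold higher number from compound 2 to compound 3 (0.07 log units; within the scatter), and the furthest is compound 1, whose number lies beyond the scatter from that of compound 3.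

The next compound is compound 4 `COc1nc2ccc(C#N)cc2cc1[C@@H](c1cccc(C)c1F)[C@@](O)(CCN(C)C)c1cc(SC)nc(SC)c1`. It differs from compound 3 in one place: methyl in place of methoxy on an aromatic carbon. Among the compounds with values here, the one measured step, cyano in place of bromo on an aromatic carbon, a 1.2-fold higher number from compound 2 to compound 3 (0.07 log units; within the scatter), concerns a different position and does not bear on this change. Compound 1 carries the same 2-fluoro-3-methylphenyl as compound 4 but also differs from compound 3 elsewhere, so its number can only be noted, not read as a step for this change. Within the data shown here, there is thus no measured step that bears on methyl in place of methoxy here, and no step beyond the scatter is expected in this assay.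

Compound 4 is expected to give about 18 uL/min in this assay, with a range of 9 uL/min to 36 uL/min, which means an expected step of a 1.1-fold lower number from compound 3 to compound 4 (0.05 log units; within the scatter).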

Compound 4, intrinsic clearance in a liver preparation (reported as CLH), per the amount of preparation that the assay uses: 13 uL/min
The estimate for compound 4 lay 1.4-fold (0.14 log units) above the measured number; low and high end bracket the measured number.
By their numbers in this assay, from the lowest: compound 1; then compounds 4, 2 and 3 (each within the scatter of the next).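

In this assay, within the data shown here, the change from 2-fluoro-3-methoxyphenyl to 2-fluoro-3-methylphenyl gives a 1.5-fold lower number from compound 3 to compound 4 (0.19 log units; within the scatter), the first measured step at this position, and at this position it does not separate methyl from methoxy on the aromatic carbon ortho to a fluoro group. Among these compounds, with the 2-fluoro-3-methylphenyl held in common, exchanging the group on the saturated chain carbon gives a 2.2-fold higher number from compound 1 to compound 4 (0.34 log units; beyond the scatter), a modest step, so the one step beyond the scatter read so far lies at that other group and not at this position. Nothing available here accounts for either step.

Open, going by these compounds, is whether other groups at this place, such as ethyl, chloro or trifluoromethyl, would also stay within the scatter of the methoxy and methyl compounds. Equally open, on these data alone, is which part of the group exchanged between compound 1 and compound 4 carries that step, and whether it would hold with methoxy in place of methyl on the fluorinated ring.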